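This account rests on a few compounds, and the source may have more. Where it says the series, first, only, none or still open, it means among the compounds named here.

Measured compounds in the cytotoxicity set:

Compound 1 `Cc1nc(C(NC(=O)C(=O)Nc2ccc(F)cc2F)C2CCCCN2)sc1CO`: in an ADME assay on TZM-b1 cells (Homo sapiens) for cytotoxicity, read by XTT assay, with a stated time of 3 days (on this read-out higher numbers stand for lower toxicity in this test and lower numbers for higher toxicity in this test), compound 1 gives > 87000 nM, which is a limit of the assay and not a number.
Compound 2 `Cc1nc(C(NC(=O)C(=O)Nc2ccc(Cl)cc2)C2CCCCN2)sc1CO`: in this assay compound 2 gives > 22000 nM, again only a limit.
Compound 3 `Cc1nc(C(NC(=O)C(=O)Nc2ccc(F)cc2F)C2CCCCN2)sc1CCO`: in this assay compound 3 gives > 84000 nM, also a limit.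

Compound 3 therefore stands nowhere in particular on the numbers shown: its own result is a limit, and the two other results are limits as well (the limit of > 22000 nM in this assay, at which 1 of the 3 values shown sits, (the limit of > 84000 nM in this assay, at which 1 of the 3 values shown sits), (the limit of > 87000 nM in this assay, at which 1 of the 3 values shown sits)). Within the data shown here, no measured compound in this set shows toxicity within the tested range.

Compound 4 `Cc1nc(C(NC(=O)C(=O)Nc2ccc(F)c(F)c2)C2CCCCN2)sc1CCO` is the next member, differing from compound 3 by 3,4-difluorophenyl in place of 2,4-difluorophenyl on an amide-type nitrogen. The measured step that touches the same place is a step that the two limits leave unreadable from compound 1 to compound 2, and the step on the saturated chain is a step that the two limits leave unreadable from compound 1 to compound 3; both are unreadable in size because each end is a limit, so they give no direction and no magnitude. Nothing in the three results suggests that moving a fluorine on the aryl amide ring brings toxicity into the measurable window. The expected step of a number no higher from compound 3 to compound 4 (the limit leaves the size open) is therefore none beyond the scatter, and compound 4 is expected to return a limit again, estimated around 84000 nM with a range from 40000 nM to 170000 nM.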

Compound 4, half-maximal cytotoxic concentration: > 78200 nM
Compound 4: only a limit was reported; the forecaster's own chance of this, stated with the estimate: 85%; the middle value does not contradict the limit.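

In this assay compound 4 gives > 78200 nM, which is a limit and not a number. Compound 3 also stands only as a limit, so no step can be read between compound 3 and compound 4. The compounds shown leave open at what concentration toxicity would appear for any of them, and whether changing the group on the amide-type nitrogen shifts it.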